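Swapping 4-(dimethylamino)phenyl for 3-hydroxyphenyl on the shared core

This account rests on a few compounds, and the source may have more. Where it says the series, first, only, none or still open, it means among the compounds named here.

Within the data shown here, compound 1 `COc1ccc(C(=O)/C=C/c2ccc(N(C)C)cc2)c2c1C=CC(C)(C)O2` is one of two compounds measured in a functional assay on HepG2 cells (Homo sapiens) for antiproliferative activity, read by MTT assay, with a stated time of 24 h (a lower number here means a stronger inhibitor, a higher number a weaker inhibitor), where compound 1 gives 730 nM. Among the measured compounds shown here, its only measured neighbour, compound 2 `CCN(CC)c1ccc(/C=C/C(=O)c2ccc(OC)c3c2OC(C)(C)C=C3)cc1`, gives 590 nM in this assay; the step of a 1.2-fold lower number from compound 1 to compound 2 (0.09 log units; within the scatter) lies within the scatter, so the two values show no real separation, even though compound 1 holds the higher of the two numbers. Compound 3 `COc1ccc(C(=O)/C=C/c2cccc(O)c2)c2c1C=CC(C)(C)O2` is not yet measured and differs from compound 1 in one place: 3-hydroxyphenyl in place of 4-(dimethylamino)phenyl on a double-bonded chain carbon bound to a double-bonded chain carbon. For the measured compounds named here, no measured step bears on this change; the one step on record, diethylamino in place of dimethylamino, was within the scatter and says nothing about trading the amino-bearing ring for a hydroxy-bearing one. For compound 3 the expected step is a 1.9-fold higher number from compound 1 to compound 3 (0.28 log units; within the scatter), a modest weakening with wide uncertainty. Compound 3 is therefore estimated to give 1400 nM in this assay, within a range from 450 nM to 4500 nM.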

Compound 3, half-maximal inhibitory concentration: > 10000 nM
Compound 3: no number, only a limit; the forecaster's own chance of this, stated with the estimate: 10%; middle value at least 7.1-fold (0.85 log units) from the limit.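

The value of compound 3 in this assay is a limit and not a number: the limit of > 10000 nM in this assay, at which 1 of the 3 values shown sits. Even so, the change can be read as an at least 13-fold higher number from compound 1 to compound 3 (1.13 log units; beyond the scatter), so the group on this double-bonded chain carbon matters in a way the earlier compounds did not reveal. Exchanging dimethylamino for diethylamino had given only a 1.2-fold lower number from compound 1 to compound 2 (0.09 log units; within the scatter), whereas replacing 4-(dimethylamino)phenyl with 3-hydroxyphenyl separates the compounds clearly.

The two ring names differ both in the group and in its number, so the compounds shown cannot say which of these goes with the weaker result. They also leave open how an unsubstituted phenyl or a ring bearing a methoxy group would read at this place on the shared core.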